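The source may hold more compounds than are shown below. What is called first, only, known or untested is meant among the compounds shown, and "the series" means these compounds.

Of the compounds shown here, three built on one shared core have been measured in a functional assay on DU-145 cells (Homo sapiens) for antiproliferative activity, read by MTT assay, with a stated time of 24 h; on this read-out lower numbers stand for stronger inhibition and higher numbers for weaker inhibition. Compound 1 `COc1ccc(/C=C/C(=O)c2cc(-c3ccc(OC)c(OC)c3)n3nc(-c4ccccc4)cc3n2)cc1` gives 14900 nM. Compound 2 `COc1ccc(-c2cc(C(=O)/C=C/c3ccc(C)cc3)nc3cc(-c4ccccc4)nn23)cc1OC` gives 19500 nM. Compound 3 `COc1ccc(-c2cc(/C=C/C(=O)c3ccc(C)cc3)nc3cc(-c4ccccc4)nn23)cc1OC` gives 26800 nM. On these numbers compound 3 holds the topmost figure, yet the two steps leading to it, a 1.8-fold higher number from compound 1 to compound 3 (0.25 log units; within the scatter) and a 1.4-fold higher number from compound 2 to compound 3 (0.14 log units; within the scatter), both lie within the scatter, as does a 1.3-fold higher number from compound 1 to compound 2 (0.12 log units; within the scatter), so the three compounds cannot be told apart by this read-out.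

Compound 4 `COc1ccc(-c2cc(/C=C/C(=O)c3ccc(C)c(C)c3)nc3cc(-c4ccccc4)nn23)cc1OC` has not yet been measured. It differs from compound 3 in one place: methyl in place of hydrogen on an aromatic carbon. Going by the values given here, no measured step adds a methyl where a hydrogen stood. The step closest in kind, a 1.3-fold higher number from compound 1 to compound 2 (0.12 log units; within the scatter), exchanges a methoxy for a methyl on an aromatic carbon and stays within the scatter, and the two changes in how the chain is arranged, a 1.8-fold higher number from compound 1 to compound 3 (0.25 log units; within the scatter) and a 1.4-fold higher number from compound 2 to compound 3 (0.14 log units; within the scatter), also stay within it. Nothing among these measurements points to a change beyond the scatter. For compound 4 the expected step is therefore a 1.0-fold lower number from compound 3 to compound 4 (0.01 log units; within the scatter). The estimate for compound 4 in this assay is 26000 nM, with a range from 12000 nM to 55000 nM.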

Compound 4, half-maximal inhibitory concentration: 12100 nM
For compound 4 the middle estimate is 2.1-fold (0.33 log units) above the measured one; low and high end bracket the measured number.
By their numbers in this assay, from the lowest: compounds 4, 1, 2 and 3 (each within the scatter of the next, the first and the last beyond it).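

In this assay, going from the 4-methylphenyl of compound 3 to the 3,4-dimethylphenyl of compound 4 gives a 2.2-fold lower number from compound 3 to compound 4 (0.35 log units; beyond the scatter) as the result of one added methyl, the first step among these compounds to clear the scatter, though only modestly. Going by these compounds alone, the methyl sits on an aromatic carbon, ortho to a methyl group and meta to a large group, and this shows that so small a change at this place can be read in this assay, whereas the earlier steps could not be told from the scatter. Compound 4 does not stand apart from the other two, with a 1.6-fold lower number from compound 2 to compound 4 (0.21 log units; within the scatter) and a 1.2-fold lower number from compound 1 to compound 4 (0.09 log units; within the scatter) both within the scatter, and nothing available here explains the step.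

Going by these compounds, it remains open whether this step belongs to the methyl itself or would also appear with another group on the same carbon, such as a fluorine, an amine or a carboxylic acid. On these data alone, it also remains open whether the same added methyl would have a similar effect on the chain arrangement of compound 2.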